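This account rests on a few compounds, and the source may have more. Where it says the series, first, only, none or still open, it means among the compounds named here.

Compound 3 `Nc1nc(-c2cccc(CO)c2)nc2sc(-c3ccco3)nc12` gives 28 nM in an assay on CHO cells for displacement of a labelled ligand from adenosine receptor A1 (Homo sapiens), read by scintillation counting, with a stated time of 3 h (on this read-out higher numbers stand for weaker inhibition and lower numbers for stronger inhibition), the lowest of the three numbers measured. Within the data shown here, compound 2 `Nc1nc(-c2ccccc2)nc2sc(-c3ccco3)nc12` gives 33 nM, and the step of a 1.2-fold lower number from compound 2 to compound 3 (0.07 log units; within the scatter) is the only single change measured. Compound 1 `COc1cccc(-c2nc(N)c3nc(-c4ccccc4)sc3n2)c1` gives 176 nM, a number beyond the scatter above compound 3. Compound 4 `COc1cccc(-c2nc(N)c3nc(-c4ccco4)sc3n2)c1` has not been measured; it differs from compound 3 by methoxy in place of hydroxymethyl on an aromatic carbon, the two having the same atoms joined differently. Among the measured compounds shown here, no measured step isolates this change: compound 1 carries the same methoxy group but also differs from compound 2 at another place, so its higher number cannot be credited to the methoxy alone. Compound 4 is therefore expected to give about 45 nM, within a range of 15 nM to 130 nM. This estimate means an expected step of a 1.6-fold higher number from compound 3 to compound 4 (0.21 log units; within the scatter).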

Compound 4, inhibition constant: 62.3 nM
Beside the measured number, compound 4's estimate is 1.4-fold (0.14 log units) below it, within the range that was stated.
By their numbers in this assay, from the lowest: compounds 3, 2 and 4 (each within the scatter of the next, the first and the last beyond it); then compound 1.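

In this assay, methoxy in place of hydroxymethyl at this position gives a 2.2-fold higher number from compound 3 to compound 4 (0.35 log units; beyond the scatter), so this read-out can tell apart these two arrangements of the same atoms, while methoxy in place of hydrogen gives a 1.9-fold higher number from compound 2 to compound 4 (0.28 log units; within the scatter) and leaves those two unseparated. With methoxy held constant, furan-2-yl in place of phenyl gives a 2.8-fold lower number from compound 1 to compound 4 (0.45 log units; beyond the scatter) and so shows that the other place also matters. Nothing here offers a measured explanation for these steps.
As far as these compounds go, whether an amine or a carboxylic acid would be tolerated at this position remains open. So does whether a longer chain, such as ethoxy, would follow methoxy or move further from hydroxymethyl.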